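Swapping the Fused Ring for a Dichlorophenyl Group

This account rests on a few compounds, and the source may have more. Where it says the series, first, only, none or still open, it means among the compounds named here.

Compound 1 `Cc1cc(=O)oc2cc(OCc3nc(N)nc(Nc4ccc(F)cc4)n3)ccc12`: 18300 nM
Compound 2 `Cc1ccc(Nc2nc(N)nc(COc3ccc4c(C)cc(=O)oc4c3)n2)cc1`: 1790 nM
Compound 3 `Cc1cc(=O)oc2cc(OCc3nc(N)nc(Nc4ccc5c(c4)COC5)n3)ccc12`: 1330 nM

All three compounds were tested in an assay on COS-7 cells for agonist activity at Free fatty acid receptor 1 (Homo sapiens), read by scintillation counting and inositol phosphate accumulation, with a stated time of 90 min; a higher number here means that more compound is needed for the effect, a lower number that less compound is needed. Compound 3 gives the lowest number of the three, but its gap to compound 2 is small: a 1.3-fold lower number from compound 2 to compound 3 (0.13 log units; within the scatter). Its gap to compound 1 is large: a 14-fold lower number from compound 1 to compound 3 (1.14 log units; beyond the scatter). The same holds for compound 2 against compound 1: a 10-fold lower number from compound 1 to compound 2 (1.01 log units; beyond the scatter).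

Compound 4 `Cc1cc(=O)oc2cc(OCc3nc(N)nc(Nc4ccc(Cl)c(Cl)c4)n3)ccc12` differs from compound 3 in one place: a group of 8 heavy atoms (6 carbon, 2 chlorine; one six-membered aromatic ring of carbon only) in place of a group of 9 heavy atoms (8 carbon, 1 oxygen; one five-membered non-aromatic ring with 1 hetero atom, one six-membered aromatic ring of carbon only), on a nitrogen on an aromatic ring. Among the measured compounds shown here, no measured step replaces the fused ring with a plain ring carrying two chlorines, so the estimate rests on the single-ring compounds. Compound 1, with a fluoro on that ring, needs far more compound than compound 3, while compound 2, with a methyl, sits close to compound 3. A plain ring can therefore land anywhere in this span, and the dichlorophenyl of compound 4 is expected to fall between those two cases, giving a 2.6-fold higher number from compound 3 to compound 4 (0.42 log units; beyond the scatter) as the expected step in this assay. Compound 4 is thus estimated at 3500 nM in this assay, with a range from 900 nM to 14000 nM.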

Compound 4, half-maximal effective concentration: 780 nM
Compound 4: middle estimate off by 4.5-fold (0.65 log units), on the high side; the measured number lies below the stated range.
By their numbers in this assay, from the lowest: compounds 4, 3 and 2 (each within the scatter of the next, the first and the last beyond it); then compound 1.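

On the nitrogen on an aromatic ring, this assay shows a 1.7-fold lower number from compound 3 to compound 4 (0.23 log units; within the scatter) when 3,4-dichlorophenyl replaces the group with the five-membered non-aromatic ring, so that second ring and its oxygen are not required for a number in this range. Among the compounds with a single six-membered aromatic ring, the substituents on that ring make a clear difference: there is a 2.3-fold lower number from compound 2 to compound 4 (0.36 log units; beyond the scatter) when 3,4-dichlorophenyl replaces 4-methylphenyl, and a 23-fold lower number from compound 1 to compound 4 (1.37 log units; beyond the scatter) when it replaces 4-fluorophenyl. No measurement available here explains why these groups give different numbers.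

The compounds shown do not separate the contribution of each chlorine, so a phenyl ring carrying only one chlorine would be needed to tell whether both contribute to the number for compound 4. They also leave open whether larger or quite different substituents on that ring, such as a methoxy group, an amine or a carboxylic acid, would continue this trend or break it.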